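A few compounds are considered here, and "the series" means these few. Any claim that something is new, unique, unknown or untested is made for them only; others in the source may bear on it.

Measured in an ADME assay on a cell-free system (plasma, Homo sapiens) for protein binding, with Plasma (Rattus norvegicus) as the target, with a stated time of 1 h; a lower number here means a smaller unbound share, a higher number a larger unbound share of the compound:
- compound 1 `CNC(=O)c1cc(F)ccc1CNC(=O)c1nc(C(C)(C)C)n(C)c(=O)c1O`: 0.07
- compound 2 `CCNC(=O)c1cc(F)ccc1CNC(=O)c1nc(C(C)(C)C)n(C)c(=O)c1O`: 0.03
- compound 3 `CCCNC(=O)c1cc(F)ccc1CNC(=O)c1nc(C(C)(C)C)n(C)c(=O)c1O`: 0.02

Compound 3 stands at the low end of these numbers, but only the gap to the methyl amide is clear: a 3.5-fold lower number from compound 1 to compound 3 (0.54 log units; beyond the scatter), against a 1.5-fold lower number from compound 2 to compound 3 (0.18 log units; within the scatter).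

The next change, (isopropyl in place of propyl on an amide-type nitrogen), gives compound 4 `CC(C)NC(=O)c1cc(F)ccc1CNC(=O)c1nc(C(C)(C)C)n(C)c(=O)c1O`, with isopropyl in place of propyl on an amide-type nitrogen. The nearest evidence comes from chain extension: a 2.3-fold lower number from compound 1 to compound 2 (0.37 log units; beyond the scatter) was modest, and a 1.5-fold lower number from compound 2 to compound 3 (0.18 log units; within the scatter) followed. Going by the values given here, no measured step covers branching, so only a small shift is expected here. The expected step is a 1.3-fold higher number from compound 3 to compound 4 (0.10 log units; within the scatter), which would not lie beyond the scatter. Compound 4 is estimated at 0.025, with an expected range of 0.015 to 0.045.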

Compound 4, unbound fraction: 0.01
Estimate against measurement, compound 4: 2.5-fold (0.40 log units) above, outside the stated range (below it).
By their numbers in this assay, from the lowest: compounds 4, 3 and 2 (each within the scatter of the next, the first and the last beyond it); then compound 1.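

On the amide-type nitrogen, isopropyl cannot be separated from propyl in this assay (with a 2.0-fold lower number from compound 3 to compound 4 (0.30 log units; within the scatter)), so branching at this position gives no clear change from the straight chain. Compound 4 does stand clearly apart from the ethyl amide (with a 3.0-fold lower number from compound 2 to compound 4 (0.48 log units; beyond the scatter)) and from the methyl amide (with a 7.0-fold lower number from compound 1 to compound 4 (0.85 log units; beyond the scatter)), a separation from the ethyl amide that compound 3 did not show. No measured evidence accounts for this result. Open, as far as these compounds go, is whether cyclopropyl, tert-butyl or a longer chain such as butyl on this nitrogen would follow compound 4, and whether an amine or a carboxylic acid on the chain would shift the unbound fraction the other way.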